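Lengthening the Saturated Chain of Compound 2

This account rests on a few compounds, and the source may have more. Where it says the series, first, only, none or still open, it means among the compounds named here.

compound 1 `CCCCCCCC(=O)Nc1cccc(-c2ccccc2)c1`: -4%
compound 2 `CCCCCCCCNc1cccc(-c2ccccc2)c1`: -20%

In an in vitro assay on BTI-TN-5B1-4 cells for inhibition of sterol O-acyltransferase 2 (Homo sapiens), tested at 50 uM (a higher number here means more inhibition at the concentration tested (going by the name of the read-out), a lower number less inhibition), compound 1 gives -4%, while compound 2 gives -20%, the lowest of the two numbers; compound 1 stands higher by a margin beyond the usual scatter. Compound 3 `CCCCCCCCCNc1cccc(-c2ccccc2)c1` differs from compound 2 by methyl in place of hydrogen on a saturated chain carbon, eight bonds along the chain from a nitrogen on an aromatic ring. Within the data shown here, no measured pair shows a change of this kind, so the step is expected to be small, within the scatter, with little change in either direction, amounting to an expected a number 5 percentage points higher from compound 2 to compound 3 (within the scatter) in this assay. Compound 3 is therefore estimated to give -15%, within a range from -35% to 5%.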

Compound 3, a percentage reported as inhibition, at one concentration (the size of the read-out at that concentration, not a potency): -8%
Compound 3: the middle estimate sits 7 percentage points below what was measured; measured number inside the range.
By their numbers in this assay, from the lowest: compound 2; then compounds 3 and 1 (each within the scatter of the next).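

In this assay, methyl in place of hydrogen on a saturated chain carbon, eight bonds along the chain from a nitrogen on an aromatic ring, gives a number 12 percentage points higher from compound 2 to compound 3 (beyond the scatter). This position therefore responds to a change of a single carbon. The read-out moves by more than the usual scatter of repeat measurements. Nothing measured here accounts for this step.

On these data alone, whether a longer chain would continue this movement remains open, as does whether a carboxylic acid or an amine in place of that methyl would move the number the same way.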